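The source may hold more compounds than are shown below. What is called first, only, known or untested is meant among the compounds shown, and "the series" means these compounds.

Measured compounds in an assay for inhibition of RAC-alpha serine/threonine-protein kinase (Homo sapiens), read by HTRF, with a stated time of 1 h; on this read-out lower numbers stand for stronger inhibition and higher numbers for weaker inhibition:
compound 1 `Cn1ncc(Cl)c1-c1cc(C(=O)N[C@@H]2CN[C@H](CCCO)C[C@H]2c2ccc(Cl)c(Cl)c2)oc1Cl` 2.56 nM
compound 2 `Cn1ncc(Cl)c1-c1cc(C(=O)N[C@@H]2CN[C@H](CCO)C[C@H]2c2ccc(Cl)c(Cl)c2)oc1Cl` 2.74 nM
compound 3 `Cn1ncc(Cl)c1-c1cc(C(=O)N[C@@H]2CN[C@H](CCN3CCCC3)C[C@H]2c2ccc(Cl)c(Cl)c2)oc1Cl` 6.41 nM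

Compound 3 holds the highest number of the three, with the step of a 2.3-fold higher number from compound 2 to compound 3 (0.37 log units; beyond the scatter) and the step of a 2.5-fold higher number from compound 1 to compound 3 (0.40 log units; beyond the scatter) both beyond the scatter, while compound 1 and compound 2 sit within the scatter of each other (a 1.1-fold higher number from compound 1 to compound 2 (0.03 log units; within the scatter)). Compound 4 `Cn1ncc(Cl)c1-c1cc(C(=O)N[C@@H]2CN[C@H](CC(=O)NC3CCC3)C[C@H]2c2ccc(Cl)c(Cl)c2)oc1Cl` has not been measured. It differs from compound 3 by cyclobutylcarbamoyl in place of (pyrrolidin-1-yl)methyl on a saturated chain carbon bound to a saturated ring carbon.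

The two steps that bear on this are those leading into compound 3: replacing hydroxymethyl or hydroxy, each with a hydrogen-bond donor, by pyrrolidin-1-yl, which has none, gave the modest rises noted above. The change to compound 4 removes pyrrolidin-1-yl again and brings in a group counted with one hydrogen-bond donor and one hydrogen-bond acceptor, though it is larger and sits one bond nearer the ring. On that basis a modest move toward lower numbers, of about the size seen in those two steps, is expected in this assay, with a plain outcome within the scatter also possible. Compound 4 is therefore estimated at 3.5 nM, range 1.5 nM to 9 nM, an expected step of a 1.8-fold lower number from compound 3 to compound 4 (0.26 log units; within the scatter).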

Compound 4, half-maximal inhibitory concentration: 7.98 nM
Estimate against measurement, compound 4: 2.3-fold (0.36 log units) below; the range from low to high includes it.
By their numbers in this assay, from the lowest: compounds 1 and 2 (each within the scatter of the next); then compounds 3 and 4 (each within the scatter of the next).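

In this assay, the new group at this position, on a saturated chain carbon bound to a saturated ring carbon, gives a 1.2-fold higher number from compound 3 to compound 4 (0.10 log units; within the scatter), so a hydrogen-bond donor in cyclobutylcarbamoyl does not by itself return the number to the level of the hydroxy-ended chains. Those chains remain apart from it, with a 2.9-fold higher number from compound 2 to compound 4 (0.46 log units; beyond the scatter) and a 3.1-fold higher number from compound 1 to compound 4 (0.49 log units; beyond the scatter), so compound 1 and compound 2 form the lower pair, while compound 3, with no donor in the changed group, and compound 4, with one, form the higher pair. Nothing measured here accounts for this split.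

Open, going by these compounds, is whether the carbonyl, the amide hydrogen or the cyclobutyl ring sets the number; a primary carboxamide, a carboxylic acid or a cyclobutylcarbamoyl on a longer chain would separate these. Also open, on these data alone, is whether a primary amine on the chain would stand with compound 1 or with compound 3.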